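This account rests on a few compounds, and the source may have more. Where it says the series, first, only, none or still open, it means among the compounds named here.

Measured compounds in this series:
- compound 1 `COc1cc(C(=O)Nc2nn[nH]n2)nc(-c2cccc(Cl)c2)c1`: 34%
- compound 2 `COc1cc(C(=O)Nc2nn[nH]n2)nc(-c2ccccc2OC)c1`: 68%
- compound 3 `CCCc1ccc(-c2cc(OC)cc(C(=O)Nc3nn[nH]n3)n2)cc1`: 93%

In a functional assay on the whole organism with Rattus norvegicus as the target, at a dose of 3 mg/kg by the oral route (on this read-out lower numbers stand for a weaker effect and higher numbers for a stronger effect at the one dose given), compound 2 stands second highest of the three numbers; compound 3 lies nearer to it, and compound 1 lies furthest from it. Going by the values given here, the single step that has been resolved on the aryl group of the shared core is a number 34 percentage points higher from compound 1 to compound 2 (beyond the scatter), showing that the identity of this aryl group moves the read-out well beyond the scatter. Among the compounds with values here, compound 3 carries a 4-propylphenyl group and gives 93%, the highest number so far, though no step between compound 2 and compound 3 is resolved here.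

The next compound, compound 4 `COc1cc(C(=O)Nc2nn[nH]n2)nc(-c2ccc(C)c(C)c2)c1`, differs from compound 2 in one place: 3,4-dimethylphenyl in place of 2-methoxyphenyl on an aromatic carbon.

Within the data shown here, only the step from compound 1 to compound 2 bears directly on a change of this aryl group, and it was large. With compound 3 at 93% and compound 2 at 68%, the two aryl groups without a methoxy substituent bracket compound 2 from both sides, so direction is uncertain. A moderate upward step is expected, a number 8 percentage points higher from compound 2 to compound 4 (within the scatter), with wide uncertainty. Compound 4 is therefore estimated at 76%, within 50% to 95%.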

Compound 4, a percentage reported as inhibition, in the whole organism at one dose (the size of the read-out at that dose, not a potency): 82%
Compound 4: the middle estimate sits 6 percentage points below what was measured; the measured number falls inside the stated range.
By their numbers in this assay, from the lowest: compound 1; then compound 2; then compound 4; then compound 3.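

In this assay the aryl position of the shared core does not depend on an oxygen-bearing group: 3,4-dimethylphenyl in place of 2-methoxyphenyl gives a number 14 percentage points higher from compound 2 to compound 4 (beyond the scatter) and so shows that a high number at this dose is reached without the methoxy group of compound 2. Going by these compounds alone, the same group in place of 3-chlorophenyl gives a number 48 percentage points higher from compound 1 to compound 4 (beyond the scatter) and is the largest step resolved at this position so far, which puts compound 1 well apart from the other aryl variants in the steps that can be read. Nothing measured alongside these numbers accounts for either step, and the aryl changes stay purely empirical for now.

The compounds shown leave open whether a single methyl group, as in 4-methylphenyl, would hold the number seen with 3,4-dimethylphenyl, and whether an amine or a carboxylic acid on this aryl ring would be compatible with the effect. As far as these compounds go, with one oral dose only, these numbers give the size of the effect and not a potency, so the order of the aryl groups at other doses also remains open.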